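Isopropyl on the amide nitrogen of a thiazole-derived FFA1 agonist

A few compounds are considered here, and "the series" means these few. Any claim that something is new, unique, unknown or untested is made for them only; others in the source may bear on it.

Measured compounds:
compound 1 `Cc1nc(-c2ccc(C(F)(F)F)cc2)sc1CNc1ccc(/C=C/C(=O)O)cc1`, 95%
compound 2 `Cc1nc(-c2ccc(C(F)(F)F)cc2)sc1CNc1ccc(C(C)CC(=O)O)cc1`, 109%
compound 3 `Cc1nc(-c2ccc(C(F)(F)F)cc2)sc1CNc1ccc(CCC(N)=O)cc1`, 88%

In a functional assay on CHO cells for agonist activity at Free fatty acid receptor 1 (Homo sapiens), read by a luciferase reporter (on this read-out higher numbers stand for larger maximal responses and lower numbers for smaller maximal responses), compound 3 gives 88%. Its distance from compound 2 is beyond the scatter, as a number 21 percentage points lower from compound 2 to compound 3 (beyond the scatter) shows, whereas the gap to compound 1, a number 7 percentage points lower from compound 1 to compound 3 (within the scatter), lies within the scatter, so compound 3 cannot be separated from compound 1 on these numbers. The remaining measured step, a number 14 percentage points higher from compound 1 to compound 2 (beyond the scatter), concerns the side chain that carries the acid and not the amide.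

Compound 4 `Cc1nc(-c2ccc(C(F)(F)F)cc2)sc1CNc1ccc(CCC(=O)NC(C)C)cc1` differs from compound 3 by isopropyl in place of hydrogen on an amide-type nitrogen. None of the three measured steps touches the amide nitrogen: the two steps that reach compound 3 exchange an acid-bearing chain for the carbamoylethyl chain, and the third exchanges one acid-bearing chain for another. Within the data shown here, there is therefore no measured step of the same kind to rest on, and the scale of what a substituent on this nitrogen does is unknown here. Under that uncertainty compound 4 is expected to stay close to compound 3, with a step of a number 3 percentage points lower from compound 3 to compound 4 (within the scatter) that is not expected to exceed the scatter. The estimate for compound 4 in this assay is 85%, in a range from 65% to 102%.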

Compound 4, largest response reached (reported as percent of maximum), in percent of the reference or control that the assay uses: 84%
The estimate for compound 4 lay 1 percentage points above the measured number; the range from low to high includes it.
By their numbers in this assay, from the lowest: compounds 4, 3 and 1 (each within the scatter of the next, the first and the last beyond it); then compound 2.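

In this assay, isopropyl in place of hydrogen on the amide-type nitrogen gives the first step seen at this position, a number 4 percentage points lower from compound 3 to compound 4 (within the scatter), so the maximal responses of the two amides cannot be separated. Set against the acid-bearing chains, the 2-(isopropylcarbamoyl)ethyl chain gives a number 25 percentage points lower from compound 2 to compound 4 (beyond the scatter), and also a number 11 percentage points lower from compound 1 to compound 4 (beyond the scatter). That second step passes the scatter where a number 7 percentage points lower from compound 1 to compound 3 (within the scatter) did not, but the two amides remain within the scatter of each other, so this small difference between the two steps does not show an effect of the isopropyl group. The data shown offer no explanation for any of these steps.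

On these data alone, whether a methyl, a cyclohexyl or a benzyl group on the same nitrogen would also stay within the scatter of the unsubstituted amide remains open, as does the outcome of a second alkyl group there, which would replace the remaining amide hydrogen. The maximal response also leaves open how the concentrations needed by these amides compare with those needed by the carboxylic acids.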